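The source may hold more compounds than are shown below. What is called first, only, known or untested is meant among the compounds shown, and "the series" means these compounds.

Working notes on the series. Within the data shown here, in a functional assay (aorta) with Rattus norvegicus as the target (on this read-out higher numbers stand for weaker inhibition and lower numbers for stronger inhibition), compound 1 `CCO/C(O)=C1\C(COCCNc2n[nH]c(O)n2)=NC(C)=C(C(=O)OC)C1c1cccc(Cl)c1Cl` gives 10 nM and compound 2 `CCO/C(O)=C1\C(COCCNc2nccc(O)n2)=NC(C)=C(C(=O)OC)C1c1cccc(Cl)c1Cl` gives 2.51 nM as the lower of the two numbers so far. Compound 3 `CCO/C(O)=C1\C(COCCNc2cc(NC)ncn2)=NC(C)=C(C(=O)OC)C1c1cccc(Cl)c1Cl` keeps the shared core of compound 2 and differs on the amine nitrogen, with 6-(methylamino)pyrimidin-4-yl in place of 4-hydroxypyrimidin-2-yl (6-(methylamino)pyrimidin-4-yl in place of 4-hydroxypyrimidin-2-yl on an amine nitrogen). Among the measured compounds shown here, the only measured step at this place is modest and beyond the scatter (a 4.0-fold lower number from compound 1 to compound 2 (0.60 log units; beyond the scatter)). It gives a scale for exchanges on this nitrogen, but no direction for the entering group. With compound 2 at 2.51 nM as the lower number, in this assay the expected step is a modest one towards a higher number (a 2.0-fold higher number from compound 2 to compound 3 (0.30 log units; within the scatter)). Compound 3 is expected at 5 nM (estimated range 1.5 nM to 16 nM).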

Compound 3, half-maximal inhibitory concentration: 3.16 nM
The estimate for compound 3 lay 1.6-fold (0.20 log units) above the measured number; the measured number falls inside the stated range.
By their numbers in this assay, from the lowest: compounds 2 and 3 (each within the scatter of the next); then compound 1.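

In this assay the exchange of 4-hydroxypyrimidin-2-yl for 6-(methylamino)pyrimidin-4-yl on the amine nitrogen gives a 1.3-fold higher number from compound 2 to compound 3 (0.10 log units; within the scatter), so the two groups cannot be told apart on this read-out, and a ring hydroxy group is not required for a number at this level. The other new step, a 3.2-fold lower number from compound 1 to compound 3 (0.50 log units; beyond the scatter), is beyond the scatter and sets both pyrimidinyl groups apart from 5-hydroxy-1H-1,2,4-triazol-3-yl in these three compounds. Nothing measured on these compounds accounts for these steps.

The compounds shown leave open whether the methylamino group itself matters, as a pyrimidin-4-yl group without it or with a dimethylamino group would show. Also open, as far as these compounds go, is how a plain phenyl ring on this nitrogen or a longer chain leading to it would read.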